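Chlorophenyl replaces dimethylaminophenyl on the saturated ring carbon

The source may report more compounds than this note shows. Statements on the series, on what has been measured and on what is new or still open speak of the compounds shown alone.

Measured so far:
compound 1 `COc1cc(/C=C/C(=O)C2=C(/C=C/c3ccc(O)c(OC)c3)NC(=O)NC2c2ccc(C)cc2)ccc1O` gives 46% in a functional assay, with a stated time of 20 min, tested at 50 uM; a lower number here means a weaker effect, a higher number a stronger effect of the compound at the concentration tested
compound 2 `COc1cc(/C=C/C(=O)C2=C(/C=C/c3ccc(O)c(OC)c3)NC(=O)NC2c2ccc(N(C)C)cc2)ccc1O` gives 56% in this assay

Compound 2 stands at the top of these two numbers, but its nearest neighbour is compound 1, and the step of a number 10 percentage points higher from compound 1 to compound 2 (within the scatter) does not separate the two beyond the scatter. Compound 3 `COc1cc(/C=C/C(=O)C2=C(/C=C/c3ccc(O)c(OC)c3)NC(=O)NC2c2ccccc2Cl)ccc1O` is not yet measured. Its change from compound 2 is 2-chlorophenyl in place of 4-(dimethylamino)phenyl on a saturated ring carbon. Going by the values given here, the only measured step, from compound 1 to compound 2, alters the same aryl group on the same saturated ring carbon and moved the read-out by a number 10 percentage points higher from compound 1 to compound 2 (within the scatter). That step shows little sensitivity of the read-out to this group, so the change to compound 3 is expected to give no step beyond the scatter, perhaps a small loss. Compound 3 is therefore estimated at 48%, between 30% and 66%, an expected step of a number 8 percentage points lower from compound 2 to compound 3 (within the scatter).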

Compound 3, a percentage reported as activity, at one concentration (the size of the read-out at that concentration, not a potency): 55.5%
Beside the measured number, compound 3's estimate is 7.5 percentage points below it, and the stated range covers the measured number.
By their numbers in this assay, from the lowest: compounds 1, 3 and 2 (each within the scatter of the next).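

Across this assay, the saturated ring carbon now carries three different aryl groups, and the new one, 2-chlorophenyl, shows a number 0.5 percentage points lower from compound 2 to compound 3 (within the scatter) and a number 9.5 percentage points higher from compound 1 to compound 3 (within the scatter) when it takes the place of the other two. Neither step separates the compounds, so the read-out at this single concentration does not distinguish 2-chlorophenyl from 4-(dimethylamino)phenyl or 4-methylphenyl, even though the new group carries chlorine and its substituent is named at a different ring position. No measurement is available that would account for this result.

The compounds shown leave open whether a carboxylic acid or a primary amine on this phenyl ring, or a short alkyl chain in place of the whole aryl group, would move the read-out beyond the scatter. They also leave open how far the result depends on the 2-(4-hydroxy-3-methoxyphenyl)ethenyl group, which all three compounds share.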